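Amine exchange on the hydroxyphenyl analogue of compound 2

The source may report more compounds than this note shows. Statements on the series, on what has been measured and on what is new or still open speak of the compounds shown alone.

Measured so far:
Compound 2 `Oc1ccc(-c2nc(N3CCCCC3)c3nc[nH]c3n2)cc1`, in an assay on cells for displacement of a labelled ligand from adenosine receptor A1 (Homo sapiens), read by scintillation counting and radioligand binding, with a stated time of 60 min (a higher number here means a weaker inhibitor, a lower number a stronger inhibitor), compound 2 gives 10 nM.
Compound 1 `CN1CCN(c2nc(-c3ccc(Cl)cc3)nc3[nH]cnc23)CC1`, in this assay compound 1 gives 398 nM.

Compound 2 holds the lowest of the two numbers; compound 1 lies higher, beyond the scatter. For the measured compounds named here, the two differ in two places at once, the aryl substituent and the amine, so no single step between them is separated.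

Compound 3 `CN1CCN(c2nc(-c3ccc(O)cc3)nc3[nH]cnc23)CC1` keeps the 4-hydroxyphenyl group of compound 2 and differs only in the amine: 4-methylpiperazin-1-yl in place of piperidin-1-yl on an aromatic carbon. Going by the values given here, the amine of compound 3 is the one carried by compound 1, whose value 398 nM is the higher of the two measured, but how much of that gap belongs to the amine is not known. A step upward from compound 2 to compound 3 of moderate size is expected, a 6.0-fold higher number from compound 2 to compound 3 (0.78 log units; beyond the scatter). Compound 3 is estimated at 60 nM, within 15 nM to 300 nM.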

Compound 3, inhibition constant: 398 nM
For compound 3 the middle estimate is 6.6-fold (0.82 log units) below the measured one; the whole stated range lies below it.
By their numbers in this assay, from the lowest: compound 2; then compounds 1 and 3 (each within the scatter of the next).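

With the 4-hydroxyphenyl group held constant, 4-methylpiperazin-1-yl in place of piperidin-1-yl on the aromatic carbon gives a 40-fold higher number from compound 2 to compound 3 (1.60 log units; beyond the scatter) in this assay, so the amine exchange alone is a large step at this position. With 4-methylpiperazin-1-yl held constant, hydroxy in place of chloro on the aromatic carbon gives no change at the digits printed from compound 1 to compound 3 (within the scatter), so this aryl exchange does not register on that amine. Nothing available bears on the reason for either result.

From the compounds shown here alone, whether hydroxy and chloro are also indistinguishable alongside piperidin-1-yl remains open. Also open, going by these compounds, is which part of the amine exchange carries the step, a question that morpholin-4-yl or an unsubstituted piperazin-1-yl at the same position could help to settle.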